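Aryl exchange on the ring nitrogen: compound 3 to compound 4

This account rests on a few compounds, and the source may have more. Where it says the series, first, only, none or still open, it means among the compounds named here.

Going by the values given here, compound 3 `N#CC1=C(N)Oc2c(N)cc3nc4ccccc4nc3c2C12C(=O)N(Cc1cnnn1-c1ccccc1Br)c1ccccc12` is the one member of the set that yields a number in a functional assay on HepG2 cells (Homo sapiens) for antiproliferative activity, read by MTT assay, with a stated time of 48 h; on this read-out lower numbers stand for stronger inhibition and higher numbers for weaker inhibition: in this assay compound 3 gives 38000 nM. Compound 1 `COc1ccccc1-n1nncc1CN1C(=O)C2(C(C#N)=C(N)Oc3c2c2nc4ccccc4nc2c2ccccc32)c2ccccc21` reaches only a limit of the assay, > 50000 nM. Compound 2 `N#CC1=C(N)Oc2c(c3nc4ccccc4nc3c3ccccc23)C12C(=O)N(Cc1cnnn1-c1ccc([N+](=O)[O-])cc1)c1ccccc12` likewise reaches only a limit, > 50000 nM. Among the compounds with values here, the single step between measured compounds, a step that the two limits leave unreadable from compound 1 to compound 2, is therefore unreadable, as the limit of > 50000 nM in this assay, at which 2 of the 3 values shown sit, shows, and it concerns a different pair of aryl groups in any case. Compound 4 `N#CC1=C(N)Oc2c(N)cc3nc4ccccc4nc3c2C12C(=O)N(Cc1cnnn1-c1c(F)cccc1F)c1ccccc12` differs from compound 3 in one place: 2,6-difluorophenyl in place of 2-bromophenyl on an aromatic nitrogen. No readable measured step touches the group on that ring nitrogen, so neither a size nor a direction can be drawn from the series for this exchange; the expectation is a step that stays within the usual scatter. Compound 4 is accordingly expected to give 45000 nM, with a range from 15000 nM to 150000 nM. The step this estimate implies from compound 3 to compound 4 is expected to be a 1.2-fold higher number from compound 3 to compound 4 (0.07 log units; within the scatter), with a real chance that only a limit is reported.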

Compound 4, half-maximal inhibitory concentration: > 50000 nM
Compound 4: a limit, no number; the forecaster's own chance of this, stated with the estimate: 45%; at least 1.1-fold (0.04 log units) between middle value and limit.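

Placing 2,6-difluorophenyl in place of 2-bromophenyl on the aromatic nitrogen gives the first step at this position that can be read at all in this assay, and only as a floor: an at least 1.3-fold higher number from compound 3 to compound 4 (0.11 log units; that floor lies within the scatter). That floor lies within the scatter, so the change is not shown to have any real effect, and it sets no size for this exchange. Compound 3 remains the only compound with a number, and the window for reading aryl exchanges here is narrow: the limit of > 50000 nM in this assay, at which 3 of the 4 values shown sit.

From the compounds shown here alone, the true distance between compound 3 and compound 4 stays open, as does whether any aryl group on this nitrogen can bring the number clearly down. Going by these compounds, what an unsubstituted phenyl or a benzyl group at this place would give also remains open.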